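Swapping a Furan for a Methoxypyridine on the Sulfonyl

This account rests on a few compounds, and the source may have more. Where it says the series, first, only, none or still open, it means among the compounds named here.

In a functional assay on the whole organism (strain Jcl:Sprague-Dawley) for inhibition, with Rattus norvegicus as the target, with stated times of 3 min and 3 h, at a dose of 1 mg/kg by the intravenous route (a lower number here means less inhibition, a higher number more inhibition at the dose given (going by the name of the read-out)), compound 1 `CNCc1cc(-c2cccnc2F)n(S(=O)(=O)c2ccsc2)c1` gives 98%. Compound 2 `CNCc1cn(S(=O)(=O)c2ccco2)c(-c2cccnc2F)c1F` stands lowest of the two measured compounds: in this assay compound 2 gives 75%, a gap to compound 1 that lies beyond the scatter. Compound 3 `CNCc1cn(S(=O)(=O)c2cc(OC)ccn2)c(-c2cccnc2F)c1F` has not yet been measured and differs from compound 2 in one place: 4-methoxypyridin-2-yl in place of furan-2-yl on a sulfonyl sulfur. Among the compounds with values here, no measured pair shows a change of this kind, so only a modest step is expected from compound 2 to compound 3, a number 5 percentage points higher from compound 2 to compound 3 (within the scatter), a small rise that may not exceed the scatter. Compound 3 is therefore expected to give 80%, within a range from 55% to 96%.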

Compound 3, a percentage reported as inhibition, in the whole organism at one dose (the size of the read-out at that dose, not a potency): 95%
Compound 3: middle estimate off by 15 percentage points, on the low side; the range from low to high includes it.
By their numbers in this assay, from the lowest: compound 2; then compounds 3 and 1 (each within the scatter of the next).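

On the sulfonyl sulfur, the choice of ring clearly matters in this assay: 4-methoxypyridin-2-yl in place of furan-2-yl gives a number 20 percentage points higher from compound 2 to compound 3 (beyond the scatter). Within the data shown here, this is the first sign that this position responds to a change of group, and that a six-membered aromatic ring can stand there without loss at this dose. Nothing available gives a reason for the rise.

The swap changes the ring and adds a methoxy group at once, so their shares stay unseparated. From the compounds shown here alone, whether a pyridine without the methoxy, or one carrying an amine instead, would give a similar number remains open.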